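Sulfanyl chain replacements on the side chain of compound 1

This account rests on a few compounds, and the source may have more. Where it says the series, first, only, none or still open, it means among the compounds named here.

Within the data shown here, compound 1 `CSCSCC1C2CCC(O2)C1C/C=C\CCCC(=O)O` gives 700 nM in a functional assay on a cell-free system (plasma) for inhibition of thromboxane A2 receptor (Homo sapiens) (a lower number here means a stronger inhibitor, a higher number a weaker inhibitor), the lowest of the three numbers known; compound 2 `CCSCC1C2CCC(O2)C1C/C=C\CCCC(=O)O` gives 5400 nM and compound 3 `CCCCCCCSCC1C2CCC(O2)C1C/C=C\CCCC(=O)O` gives 42000 nM. Compound 4 `CCC/C=C(\C)CSCC1C2CCC(O2)C1C/C=C\CCCC(=O)O` differs from compound 1 as follows: a group of 6 heavy atoms (6 carbon; no ring) in place of a group of 2 heavy atoms (1 carbon, 1 sulfur; no ring), on a saturated chain carbon bound to a sulfur. Among the measured compounds shown here, two measured steps bear on this change. a 7.7-fold higher number from compound 1 to compound 2 (0.89 log units; beyond the scatter); a 60-fold higher number from compound 1 to compound 3 (1.78 log units; beyond the scatter). For the measured compounds named here, the group entering compound 4 matches hexyl in its count of carbons, with one double bond added, so a large rise is expected in this assay, close to that seen for compound 3, though no measured step covers a double bond in this group. For compound 4 the estimate is 20000 nM (range 5000 nM to 80000 nM), meaning an expected 29-fold higher number from compound 1 to compound 4 (1.46 log units; beyond the scatter).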

Compound 4, half-maximal inhibitory concentration: 1100 nM
For compound 4 the middle estimate is 18-fold (1.26 log units) above the measured one; the whole stated range lies above it.
By their numbers in this assay, from the lowest: compounds 1 and 4 (each within the scatter of the next); then compound 2; then compound 3.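

In this assay, carbon count alone does not set the number at this saturated chain carbon bound to a sulfur: hexyl and the group with one double bond share a count, yet the data show a 38-fold lower number from compound 3 to compound 4 (1.58 log units; beyond the scatter). The group with one double bond also stands apart from the short chain, with a 4.9-fold lower number from compound 2 to compound 4 (0.69 log units; beyond the scatter), while a 1.6-fold higher number from compound 1 to compound 4 (0.20 log units; within the scatter) shows that methylsulfanyl is not needed for a number of this size. No evidence at hand accounts for these differences. Still open, going by these compounds, is whether the double bond alone carries the gap to compound 3, and how a phenyl ring or an amine would read at this place.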